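The source may report more compounds than this note shows. Statements on the series, on what has been measured and on what is new or still open speak of the compounds shown alone.

Measured compounds:
- compound 1, `Cc1cc(C(=O)/C=C/c2cc3cccc(C)c3nc2Cl)c(C)s1`: "not determined" (no result reported)
- compound 2, `Cc1ccc2nc(Cl)c(/C=C/C(=O)c3cc(C)sc3C)cc2c1`: 229 nM

Compound 1 has no single number in a functional assay on HUVEC cells (Homo sapiens), read by BrdU incorporation, with a stated time of 72 h; on this read-out higher numbers stand for weaker inhibition and lower numbers for stronger inhibition; its result there stands as "not determined" (no result reported). Compound 2 does have one: in this assay compound 2 gives 229 nM, and it is the only firm point in this small set. Within the data shown here, no step between two measured compounds is given, so no measured change can be compared with the one that leads to compound 3.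

Compound 3, `Cc1cccc2cc(/C=C/C(=O)c3ccc(Cl)s3)c(Cl)nc12`, differs from compound 1 in one place: 5-chlorothiophen-2-yl in place of 2,5-dimethylthiophen-3-yl on a carbonyl carbon. With no number for compound 1, the move from compound 1 to compound 3 cannot be sized from data; it is expected to stay within the usual scatter of this assay, in no set direction, with compound 2 as the nearest anchor. Compound 3 is therefore estimated at 300 nM, within the range 80 nM to 1500 nM.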

Compound 3, half-maximal inhibitory concentration: 116 nM
For compound 3 the middle estimate is 2.6-fold (0.41 log units) above the measured one; measured number inside the range.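

Among these compounds, compound 1 has no single number in this assay, so no step from it to compound 3 can be read. On these data alone, what putting 5-chlorothiophen-2-yl in place of 2,5-dimethylthiophen-3-yl does to inhibition stays open. No supporting evidence bears on this result.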